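Swapping Chloro for Methyl on a Shared Core

The source may hold more compounds than are shown below. What is called first, only, known or untested is meant among the compounds shown, and "the series" means these compounds.

Three measured compounds share one core and differ only in the group on the outer six-membered ring: compound 1 `CCOc1ccc(NC2=CC(=O)c3ncncc3C2=O)cc1` carries ethoxy, compound 2 `O=C1C(Nc2ccc(I)cc2)=CC(=O)c2ncncc21` iodo, and compound 3 `O=C1C(Nc2ccc(Cl)cc2)=CC(=O)c2ncncc21` chloro. In a functional assay on SK-MEL-2 cells (Homo sapiens) for cytotoxicity, read by MTT assay, with a stated time of 72 h (on this read-out higher numbers stand for weaker inhibition and lower numbers for stronger inhibition), compound 1 gives 0.02 ug/mL, compound 2 gives 0.02 ug/mL, and compound 3 gives 0.01 ug/mL. On these numbers compound 3 holds the lowest figure, yet the steps of a 2.0-fold lower number from compound 1 to compound 3 (0.30 log units; within the scatter) and a 2.0-fold lower number from compound 2 to compound 3 (0.30 log units; within the scatter) both stay within the scatter, as does no change at the digits printed from compound 1 to compound 2 (within the scatter), so compound 3 cannot be called the most active of the three. Compound 4 `Cc1ccc(NC2=CC(=O)c3ncncc3C2=O)cc1` is the next step: methyl in place of chloro on an aromatic carbon. The three steps just named all bear on it, since each exchanged the group at this same place, and none moved the number beyond the scatter. No step beyond the scatter is therefore expected in this assay, and the estimated step is a 2.0-fold higher number from compound 3 to compound 4 (0.30 log units; within the scatter). Compound 4 is expected to give about 0.02 ug/mL, within a range from 0.005 ug/mL to 0.08 ug/mL.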

Compound 4, half-maximal inhibitory concentration: 0.02 ug/mL
Compound 4: the middle estimate sits on the measured number at the digits printed; the measured number falls inside the stated range.
By their numbers in this assay, from the lowest: compounds 3, 1, 2 and 4 (each within the scatter of the next).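

In this assay, methyl now joins ethoxy, iodo and chloro at this place, para to a large group, and the new compound gives a 2.0-fold higher number from compound 3 to compound 4 (0.30 log units; within the scatter) together with no change at the digits printed from compound 2 to compound 4 (within the scatter) and no change at the digits printed from compound 1 to compound 4 (within the scatter). A group holding a single carbon therefore sits within the scatter of a chlorine, an iodine and the ethoxy group, so the four compounds cannot be ranked against one another, and this assay read-out shows no sensitivity to any of these four exchanges at this place. No measurement shown here accounts for this lack of separation.

Still open, going by these compounds, is whether an amine, a carboxylic acid or a longer chain at this place would also stay within the scatter. Equally open, on these data alone, is whether changes elsewhere on the shared core would leave the number as steady.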